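Cyclobutyl to Methyl on a Ring Nitrogen

A few compounds are considered here, and "the series" means these few. Any claim that something is new, unique, unknown or untested is made for them only; others in the source may bear on it.

Of the compounds shown here, three sharing one core have been measured in an assay on RMS13 cells for displacement of a labelled ligand from Urotensin-2 receptor (Homo sapiens), read by scintillation proximity assay; a higher number here means a weaker inhibitor, a lower number a stronger inhibitor. Compound 1 `CCN1CCN(c2cccc3c2CN([C@H](CCCNC(=O)c2c(C)n[nH]c2C)c2ccc(OC)c(OC)c2)C3=O)CC1` gives 11 nM. Compound 2 `CCN1CCN(c2cccc3c2CN([C@H](CCCNS(=O)(=O)c2c[nH]cn2)c2ccc(OC)c(OC)c2)C3=O)CC1` gives 25 nM, and the change between them is a 2.3-fold higher number from compound 1 to compound 2 (0.36 log units; beyond the scatter). Compound 3 `COc1ccc([C@@H](CCCN(C)S(=O)(=O)c2cccs2)N2Cc3c(cccc3N3CCN(C4CCC4)CC3)C2=O)cc1OC` gives 44 nM, the highest of the three numbers; its gap to compound 2 lies within the usual scatter, while the number of compound 1 sits below it by a gap beyond the scatter.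

Compound 4 `COc1ccc([C@@H](CCCN(C)S(=O)(=O)c2cccs2)N2Cc3c(cccc3N3CCN(C)CC3)C2=O)cc1OC` has not been measured. It differs from compound 3 by methyl in place of cyclobutyl on an amine nitrogen in a ring. Among the measured compounds shown here, the one measured step, from compound 1 to compound 2, alters the group on an amine nitrogen that is not the ring nitrogen changed here, so it does not bear on this change. For the measured compounds named here, nothing among the measured compounds addresses a smaller group on this ring nitrogen. The expected step in this assay is therefore a 1.4-fold higher number from compound 3 to compound 4 (0.13 log units; within the scatter), which is no step beyond the scatter. Compound 4 is expected to give about 60 nM, with a range from 25 nM to 150 nM.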

Compound 4, inhibition constant: < 6 nM
Compound 4 gave a limit, no number; the forecaster's own chance of this, stated with the estimate: 5%; middle value at least 10-fold (1.00 log units) away from the limit.
By their numbers in this assay, from the lowest: compound 1; then compounds 2 and 3 (each within the scatter of the next). At a limit, below all of these: compound 4.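

At this amine nitrogen in a ring, the group matters: in this assay, methyl in place of cyclobutyl gives an at least 7.3-fold lower number from compound 3 to compound 4 (0.86 log units; beyond the scatter), and a lower number here means a stronger inhibitor. Among the compounds shown here, compound 4 sits at a limit of the assay and not at a number, so the step has a floor but no known full size: the limit of < 6 nM in this assay, at which 1 of the 4 values shown sits. The one earlier step concerned a different amine nitrogen, so this pair is the first to show the effect of changing the ring nitrogen's group alone.

One pair cannot say whether the number follows the size of the group, since the ethyl group of compound 1 and compound 2 comes with other changes to the molecule. As far as these compounds go, how this nitrogen behaves with a plain hydrogen, an isopropyl group or an acetyl group remains open.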